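The source may report more compounds than this note shows. Statements on the series, on what has been measured and on what is new or still open speak of the compounds shown alone.

Measured compounds in a functional assay, with a stated time of 10 min; on this read-out higher numbers stand for weaker inhibition and lower numbers for stronger inhibition:

compound 1, `Cn1c(NN)nc(-c2ccco2)c(C#N)c1=O`, 58 ug/mL
compound 2, `CCOC(=O)c1cnn(-c2nc(-c3cccs3)c(C#N)c(=O)n2C)c1N`, 109 ug/mL

Compound 2 stands at the top of the two numbers in this assay, but its gap to compound 1 lies within the usual scatter, so the two cannot be set apart on this read-out and no order between them is claimed. Going by the values given here, no step between measured compounds that differ in one place is available in this set, so there is no measured reference for the size a single change can bring in this assay.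

Compound 3, `CCOC(=O)c1cnn(-c2nc(-c3cccc(O)c3O)c(C#N)c(=O)n2C)c1N`, is the next compound to be measured in this assay. It differs from compound 2 in one place: 2,3-dihydroxyphenyl in place of thiophen-2-yl on an aromatic carbon. Without a measured step of this kind, the expectation rests only on compound 2 and its value, 109 ug/mL, and the change itself. The step of a 1.4-fold lower number from compound 2 to compound 3 (0.13 log units; within the scatter) is expected to be modest and is not expected to reach clearly beyond the scatter in either direction. Compound 3 is therefore estimated at 80 ug/mL, within a range of 30 ug/mL to 200 ug/mL.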

Compound 3, half-maximal inhibitory concentration: 53 ug/mL
Beside the measured number, compound 3's estimate is 1.5-fold (0.18 log units) above it, within the range that was stated.
By their numbers in this assay, from the lowest: compounds 3, 1 and 2 (each within the scatter of the next, the first and the last beyond it).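

In this assay, going by these compounds alone, 2,3-dihydroxyphenyl in place of thiophen-2-yl, on the aromatic carbon ortho to a cyano group, gives the first step between compounds that differ in one place: a 2.1-fold lower number from compound 2 to compound 3 (0.31 log units; beyond the scatter). This position therefore takes a six-membered aromatic ring of carbon only, with more heavy atoms than thiophen-2-yl, without a rise in the number, and the step, though modest, lies just beyond the scatter. No measurement available here bears on what lies behind the step.

Within the data shown here, the change replaces the ring and adds the hydroxyl groups in one move, so the single step cannot show how much of it belongs to the six-membered ring and how much to the hydroxyl groups; unsubstituted phenyl, a single hydroxyl group or methoxy groups in their place would separate these parts. Also open, going by these compounds, is whether the position responds in the same direction to quite different groups, such as an amine or a carboxylic acid on the phenyl ring, or to other five-membered rings such as furan-2-yl on the core of compound 2.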